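The compounds below may be only part of what the source reports. "The series", "measured", "known", "first", "only" and "open" are said of these compounds alone.

Measured so far in a functional assay on NCI-H460 cells (Homo sapiens) for cytotoxicity, read by MTT assay, with a stated time of 72 h; a lower number here means a stronger inhibitor, a higher number a weaker inhibitor:
- compound 1 `O=c1[nH]/c(=C\c2ccccn2)c(=O)[nH]/c1=C\c1cccc(Oc2ccc(F)cc2)c1`: 49.1 nM
- compound 2 `O=c1[nH]/c(=C\C2CCCCC2)c(=O)[nH]/c1=C\c1cccc(Oc2ccc(F)cc2)c1`: > 1000 nM, a limit
- compound 3 `O=c1[nH]/c(=C\c2ccc([N+](=O)[O-])o2)c(=O)[nH]/c1=C\c1cccc(Oc2ccc(F)cc2)c1`: > 1000 nM, a limit

Compound 3 stands at the limit of > 1000 nM in this assay, at which 2 of the 3 values shown sit, so it has a limit and no exact number. Compound 4 `COCc1ccc(/C=c2\[nH]c(=O)/c(=C/c3cccc(Oc4ccc(F)cc4)c3)[nH]c2=O)o1` differs from it as follows: methoxymethyl in place of nitro on an aromatic carbon. In words, methoxymethyl replaces nitro on an aromatic carbon.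

Going by the values given here, no measured step makes this exact change. The closest evidence comes from swapping the whole group on the chain carbon: an at least 20-fold higher number from compound 1 to compound 3 (1.30 log units; beyond the scatter) and an at least 20-fold higher number from compound 1 to compound 2 (1.30 log units; beyond the scatter). Both steps are large, so this group can matter greatly. Only compound 1 gives a measured number, 49.1 nM, so a moderate move toward a lower number is expected. Compound 4 may still reach the limit. The expected change is an at least 2.0-fold lower number from compound 3 to compound 4 (0.30 log units; that floor lies within the scatter). For compound 4, the estimated value is 500 nM, with an expected range of 100 nM to 1500 nM.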

Compound 4, half-maximal inhibitory concentration: 14 nM
Estimate against measurement, compound 4: 36-fold (1.55 log units) above, and the stated range ends above it.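

In this assay, swapping nitro for methoxymethyl on the furan gives an at least 71-fold lower number from compound 3 to compound 4 (1.85 log units; beyond the scatter) and so turns a compound with no exact number into a strong one, while replacing cyclohexyl with the 5-(methoxymethyl)furan-2-yl group gives an at least 71-fold lower number from compound 2 to compound 4 (1.85 log units; beyond the scatter) on the same scale. The 5-(methoxymethyl)furan-2-yl group also outdoes pyridin-2-yl, with a 3.5-fold lower number from compound 1 to compound 4 (0.54 log units; beyond the scatter) in this series. Compound 2 and compound 3 each hold only a limit, so both large steps are floors and the step between those two cannot be read: the limit of > 1000 nM in this assay, at which 2 of the 4 values shown sit.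

On these data alone, whether an amine, a carboxylic acid or a longer ether chain at this furan carbon would hold the activity stays open.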